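This account rests on a few compounds, and the source may have more. Where it says the series, first, only, none or still open, it means among the compounds named here.

Compound 3 `COc1ccc(N(C)c2nc(C)nc3ccccc23)cc1C[Se]C#N` gives the lowest number of the three measured compounds in a functional assay on A549 cells (Homo sapiens) for inhibition, read by MTT assay, with a stated time of 48 h (a lower number here means a stronger inhibitor, a higher number a weaker inhibitor), at 98 nM. Compound 1 `COc1ccc(N(C)c2nc(C)nc3ccccc23)cc1C(=O)OCCC[Se]C#N` stands nearest to it, with 250 nM, and compound 2 `COc1ccc(N(C)c2nc(C)nc3ccccc23)cc1OCCCCCC[Se]C#N` furthest, with 5520 nM; the gaps are a 2.6-fold lower number from compound 1 to compound 3 (0.41 log units; beyond the scatter) and a 56-fold lower number from compound 2 to compound 3 (1.75 log units; beyond the scatter). Compound 4 `COc1ccc(N(C)c2nc(C)nc3ccccc23)cc1OCCC[Se]C#N` has not yet been measured. Its change from compound 3 is a group of 7 heavy atoms (4 carbon, 1 nitrogen, 1 oxygen, 1 selenium; no ring) in place of a group of 4 heavy atoms (2 carbon, 1 nitrogen, 1 selenium; no ring), on an aromatic carbon.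

Among the compounds with values here, three measured steps bear on this. The step of a 2.6-fold lower number from compound 1 to compound 3 (0.41 log units; beyond the scatter) shows that replacing the group of 4 heavy atoms by a longer chain on the same aromatic carbon costs only a modest amount. The step of a 22-fold higher number from compound 1 to compound 2 (1.34 log units; beyond the scatter) shows that a still longer chain carrying an oxygen directly on the ring costs much more, and a 56-fold lower number from compound 2 to compound 3 (1.75 log units; beyond the scatter) sums the two. The group entering in compound 4 is closer in size to that of compound 1 than to that of compound 2, while, like compound 2, it places an oxygen on the aromatic carbon. The author therefore expects an upward step of moderate size, a 5.1-fold higher number from compound 3 to compound 4 (0.71 log units; beyond the scatter), beyond the scatter yet short of the large step seen toward compound 2. For compound 4 he estimates 500 nM in this assay, with a range from 150 nM to 2500 nM.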

Compound 4, half-maximal inhibitory concentration: 382 nM
Beside the measured number, compound 4's estimate is 1.3-fold (0.12 log units) above it; low and high end bracket the measured number.
By their numbers in this assay, from the lowest: compound 3; then compounds 1 and 4 (each within the scatter of the next); then compound 2.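

With the oxygen on the aromatic carbon held constant in this assay, the step of a 14-fold lower number from compound 2 to compound 4 (1.16 log units; beyond the scatter) changes only the chain length, so the large loss at compound 2 cannot be assigned to the ring oxygen alone and goes with the longer chain. The step of a 3.9-fold higher number from compound 3 to compound 4 (0.59 log units; beyond the scatter) shows that the oxygen-linked chain, on this aromatic carbon ortho to a methoxy group, costs only a modest amount against the smaller group of compound 3, while the step of a 1.5-fold higher number from compound 1 to compound 4 (0.18 log units; within the scatter) lies within the scatter and so does not separate the chain of compound 4 from the carbonyl-bearing chain of compound 1. No measurement of any other property accompanies these numbers to account for the steps.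

The compounds shown leave open how the number moves for oxygen-linked chains of intermediate length between those of compound 4 and compound 2, and for a chain shorter than that of compound 4. They also leave open whether an amine within the chain, or sulfur in place of the selenium, would preserve the numbers seen here.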